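This account rests on a few compounds, and the source may have more. Where it says the series, first, only, none or still open, it means among the compounds named here.

Measured in an assay on CHO cells for displacement of a labelled ligand from 5-hydroxytryptamine receptor 1B (Homo sapiens); on this read-out higher numbers stand for weaker inhibition and lower numbers for stronger inhibition:
- compound 1 `O[C@@H]1Cc2ccccc2[C@H]1NC1CCN(CCCc2c[nH]c3ccc(-n4cnnc4)cc23)CC1` gives 210 nM
- compound 2 `c1cc(CNC2CCN(CCCc3c[nH]c4ccc(-n5cnnc5)cc34)CC2)co1` gives 78 nM
- compound 3 `CN(Cc1ccco1)C1CCN(CCCc2c[nH]c3ccc(-n4cnnc4)cc23)CC1` gives 89 nM

Compound 3 has the second highest of the three numbers. Its nearest neighbour is compound 2, with a 1.1-fold higher number from compound 2 to compound 3 (0.06 log units; within the scatter); its furthest is compound 1, with a 2.4-fold lower number from compound 1 to compound 3 (0.37 log units; beyond the scatter). Compound 4 `c1ccc(NCC2CCN(CCCc3c[nH]c4ccc(-n5cnnc5)cc34)CC2)nc1` differs from compound 3 in one place: ((pyridin-2-yl)amino)methyl in place of ((furan-2-yl)methyl)(methyl)amino on a saturated ring carbon. Among the measured compounds shown here, the steps that bear on this position are a 2.7-fold lower number from compound 1 to compound 2 (0.43 log units; beyond the scatter) and a 2.4-fold lower number from compound 1 to compound 3 (0.37 log units; beyond the scatter), both modest, while a 1.1-fold higher number from compound 2 to compound 3 (0.06 log units; within the scatter) shows that swapping between two small groups at this carbon can leave the number unchanged. For the measured compounds named here, no measured compound carries a pyridinylamino methyl group, so the direction is uncertain; a step of modest size is expected, a 1.3-fold higher number from compound 3 to compound 4 (0.13 log units; within the scatter). Compound 4 is therefore estimated at 120 nM, within 40 nM to 400 nM.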

Compound 4, half-maximal inhibitory concentration: 3.3 nM
The estimate for compound 4 lay 36-fold (1.56 log units) above the measured number, outside the stated range (below it).
By their numbers in this assay, from the lowest: compound 4; then compounds 2 and 3 (each within the scatter of the next); then compound 1.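

In this assay, among the compounds shown here, the saturated ring carbon proves far more sensitive than the earlier compounds showed: ((pyridin-2-yl)amino)methyl brings a 27-fold lower number from compound 3 to compound 4 (1.43 log units; beyond the scatter) and a 24-fold lower number from compound 2 to compound 4 (1.37 log units; beyond the scatter) and a 64-fold lower number from compound 1 to compound 4 (1.80 log units; beyond the scatter) even though the earlier changes there were modest or within the scatter. The group that enters has the same heavy-atom count as the group that leaves, so that count does not separate them. Nothing measured here accounts for the gain.

The compounds shown leave open whether the pyridin-2-yl ring or the aminomethyl link carries this step. A phenyl ring or a pyridin-3-yl ring on the same link would separate the two.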